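Fluoro, chloro and methyl on the shared core

The source may hold more compounds than are shown below. What is called first, only, known or untested is meant among the compounds shown, and "the series" means these compounds.

Measured in a physicochemical assay for solubility, in phosphate buffer, at pH 7.4; a higher number here means a more soluble compound, a lower number a less soluble compound:
- compound 1 `CC(=O)N[C@@H]1CCC[C@H](C(=O)Nc2cc(-c3cnn4c3CC(C)(C)C4)c(F)cn2)C1`: 550000 nM
- compound 2 `CC(=O)N[C@@H]1CCC[C@H](C(=O)Nc2cc(-c3cnn4c3CC(C)(C)C4)c(Cl)cn2)C1`: 150000 nM

Compound 2, at 150000 nM, holds the lower of the two numbers in this assay. Compound 3 `CC(=O)N[C@@H]1CCC[C@H](C(=O)Nc2cc(-c3cnn4c3CC(C)(C)C4)c(C)cn2)C1`, not yet measured, differs from compound 2 in one place: methyl in place of chloro on an aromatic carbon. This is methyl in place of chloro on an aromatic carbon of a six-membered aromatic ring with 1 nitrogen.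

Among the compounds with values here, only one measured step bears on it: a 3.7-fold lower number from compound 1 to compound 2 (0.56 log units; beyond the scatter), a modest change, with chloro in place of fluoro on an aromatic carbon. Within the data shown here, no measured compound carries methyl there, so that step is a loose guide. A small rise in this assay is expected, probably within the scatter and smaller than the measured step. The expected step is a 1.5-fold higher number from compound 2 to compound 3 (0.17 log units; within the scatter). For compound 3 the estimated value is 220000 nM, with an expected range of 90000 nM to 550000 nM.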

Compound 3, solubility: 600000 nM
Compound 3: the middle estimate sits 2.7-fold (0.44 log units) below what was measured, and the stated range ends below it.
By their numbers in this assay, from the lowest: compound 2; then compounds 1 and 3 (each within the scatter of the next).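

Methyl in place of chloro gives a 4.0-fold higher number from compound 2 to compound 3 (0.60 log units; beyond the scatter) in this assay, while methyl in place of fluoro gives a 1.1-fold higher number from compound 1 to compound 3 (0.04 log units; within the scatter), so methyl and fluoro cannot be told apart at this position. Of the three groups on this aromatic carbon, only chloro separates from the others: compound 2 has steps beyond the scatter to both compound 1 and compound 3, although the swap from chloro to methyl exchanges only one heavy atom for one heavy atom, with no hydrogen-bond donors or acceptors on either side. Nothing at hand accounts for this separation.

From the compounds shown here alone, how an amine, a methoxy group or a longer alkyl chain on this carbon would read in this assay stays open. Also open, going by these compounds, is whether compound 2 would stand apart in the same way on a different core.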